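Bromo for fluoro at the shared core of compound 3

The source may report more compounds than this note shows. Statements on the series, on what has been measured and on what is new or still open speak of the compounds shown alone.

Measured compounds:
Compound 1, `CCOc1ccc(C(=O)Nc2cccc(NC(=O)COc3ccc4c(=O)ccoc4c3)c2)cc1`, 17 nM
Compound 2, `Cc1cc(NC(=O)COc2ccc3c(=O)ccoc3c2)cc(NC(=O)c2ccc(N(C)C)cc2)c1`, > 10000 nM
Compound 3, `CN(C)c1ccc(C(=O)Nc2cc(F)cc(NC(=O)COc3ccc4c(=O)ccoc4c3)c2)cc1`, 49 nM

In an assay on isolated protein for inhibition of Rho-associated protein kinase 1 (Homo sapiens), read by scintillation counting, radiometric assay and 33P incorporation, with a stated time of 40 min, in the presence of a further agent that is not named here (on this read-out higher numbers stand for weaker inhibition and lower numbers for stronger inhibition), compound 3 gives 49 nM, the higher of the two numbers shown. Its nearest neighbour is compound 1, which gives 17 nM in this assay. Compound 2 is reported only as a limit of this assay, > 10000 nM, and not as a number (the limit of > 10000 nM in this assay, at which 1 of the 3 values shown sits).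

Compound 4, `CN(C)c1ccc(C(=O)Nc2cc(Br)cc(NC(=O)COc3ccc4c(=O)ccoc4c3)c2)cc1`, has not yet been measured. It differs from compound 3 in one place: bromo in place of fluoro on an aromatic carbon. Within the data shown here, the one measured step that touches this position is the change from methyl to fluoro, an at least 200-fold lower number from compound 2 to compound 3 (2.30 log units; beyond the scatter), a large step in which the number fell away from a limit. Among the measured compounds shown here, no step from fluoro to bromo, or from methyl to bromo, has been measured, so the direction of the new step cannot be read from the data with confidence. Because the methyl compound sat at the limit of > 10000 nM in this assay, at which 1 of the 3 values shown sits, while the fluoro compound gave a number, a move to bromo is expected to raise the number, by a 6.1-fold higher number from compound 3 to compound 4 (0.79 log units; beyond the scatter). Compound 4 is therefore estimated at 300 nM in this assay, within a range from 40 nM to 5000 nM.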

Compound 4, half-maximal inhibitory concentration: > 10000 nM
Compound 4: only a limit was reported; the forecaster's own chance of this, stated with the estimate: 25%; middle value at least 33-fold (1.52 log units) away from the limit.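

Placing bromo where compound 3 carries fluoro gives an at least 200-fold higher number from compound 3 to compound 4 (2.30 log units; beyond the scatter) in this assay, so a single-atom exchange at this aromatic carbon is enough to take the series from a measurable number to a limit. The earlier step had shown a sharp response at this position only for methyl and fluoro, and with bromo added, fluoro is the only one of the three groups on this otherwise shared structure that gives a number rather than a limit. Compound 2 and compound 4 both stand as limits, so the step between them cannot be read and the methyl and bromo compounds cannot be put in order: the limit of > 10000 nM in this assay, at which 2 of the 4 values shown sit.

As far as these compounds go, whether chloro, a hydroxyl or a methoxy group at this position, with the rest of compound 3 kept, would give a number or a limit remains open. Also open, from the compounds shown here alone, is whether bromo would give a limit on the structure of compound 1, which carries an ethoxy group and has neither fluoro nor bromo at this position.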